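The source may report more compounds than this note shows. Statements on the series, on what has been measured and on what is new or still open speak of the compounds shown alone.

Compound 1 `Cn1c(Cc2nn(C)c(=O)c3ccccc23)nnc1SCCCCCCCC(=O)Nc1ccc(Cl)cc1Cl` gives 2200 nM in an assay on 32D cells for inhibition of interleukin-15 (Mus musculus), read by resazurin assay, with stated times of 30 min and 2.5 days, in the presence of a further agent that is not named here; on this read-out higher numbers stand for weaker inhibition and lower numbers for stronger inhibition.
Compound 2 `Cn1nc(Cc2nnc(SCCCCCCCC(=O)Nc3ccc(Cl)cc3Cl)[nH]2)c2ccccc2c1=O` gives 1100 nM in this assay.
Compound 3 `Cn1nc(Cc2nnc(SCCCCCCCC(=O)Nc3ccc(Cl)cc3Cl)n2CCCO[Si](C)(C)C(C)(C)C)c2ccccc2c1=O` gives only a limit in this assay, > 30000 nM.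

Among the two plain numbers, compound 1 stands highest, with compound 2 nearest: from compound 1 to compound 2 the change is a 2.0-fold lower number from compound 1 to compound 2 (0.30 log units; within the scatter), so the two cannot be ordered. Compound 4 `Cn1c(Cc2nn(CCC=O)c(=O)c3ccccc23)nnc1SCCCCCCCC(=O)Nc1ccc(Cl)cc1Cl` differs from compound 1 by formylmethyl in place of hydrogen on a saturated chain carbon bound to an aromatic nitrogen. Among the compounds with values here, two measured steps touch the same place. Compound 3 carries a far larger group there, and the step from compound 1 to compound 3 was an at least 13-fold higher number from compound 1 to compound 3 (1.13 log units; beyond the scatter), while that from compound 2 to compound 3 was an at least 27-fold higher number from compound 2 to compound 3 (1.43 log units; beyond the scatter); compound 3 sits at the limit of > 30000 nM in this assay, at which 1 of the 3 values shown sits. The group entering in compound 4 is much smaller than that of compound 3, so a weakening is expected, but a gentler one than the steps to compound 3 show. Compound 4 is therefore estimated at 6000 nM, with a range from 2000 nM to 20000 nM. That expected step, a 2.7-fold higher number from compound 1 to compound 4 (0.44 log units; beyond the scatter), would lie beyond the scatter.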

Compound 4, half-maximal inhibitory concentration: 8900 nM
Compound 4: the middle estimate sits 1.5-fold (0.17 log units) below what was measured, and the stated range covers the measured number.
By their numbers in this assay, from the lowest: compounds 2 and 1 (each within the scatter of the next); then compound 4. At a limit, above all of these: compound 3.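

In this assay, within the data shown here, replacing hydrogen with formylmethyl on a saturated chain carbon bound to an aromatic nitrogen gives a 4.0-fold higher number from compound 1 to compound 4 (0.61 log units; beyond the scatter), the first step at this kind of place whose size can be read as a plain number. Compound 3 gives only a limit, so its steps set no size: the limit of > 30000 nM in this assay, at which 1 of the 4 values shown sits. Compound 4, by contrast, shows that a group of this size lowers inhibition modestly without abolishing a measurable value, so the place tolerates the 2-formylethyl chain in place of methyl to that degree.

The compounds shown leave open whether the carbonyl or the chain itself accounts for the step. A plain propyl chain, a carboxylic acid or an amine at the chain end, or a longer chain could separate these possibilities.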